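One Amide Substituent Changed: From Compound 2 to Compound 4

The source may report more compounds than this note shows. Statements on the series, on what has been measured and on what is new or still open speak of the compounds shown alone.

Compound 1 `CC(C)c1noc(N2CCN(C(=O)[C@@H]3CCCN(S(=O)(=O)c4ccc(S(=O)(=O)C(C)C)cc4)C3)CC2)n1`: 70 nM
Compound 2 `CCN(CC)S(=O)(=O)c1ccc(S(=O)(=O)N2CCC[C@@H](C(=O)N[C@@H]3CCN(C(=O)OC(C)(C)C)C3)C2)cc1`: 200 nM
Compound 3 `CCOC(=O)N1CCC[C@@H](S(=O)(=O)c2ccc(S(=O)(=O)N(CC)CC)cc2)C1`: a limit, > 30000 nM

All three compounds were tested in a functional assay on MIA PaCa-2 cells (Homo sapiens) for inhibition, read by MTT assay, with a stated time of 7 days; a lower number here means a stronger inhibitor, a higher number a weaker inhibitor. Only two of them give a number. Compound 1 gives 70 nM and compound 2 gives 200 nM, so compound 2 stands as the higher, weaker of the two, and the gap between them lies beyond the usual scatter. Compound 3 gives no number at all, only a limit, > 30000 nM; the note the limit of > 30000 nM in this assay, at which 1 of the 3 values shown sits, records that one of the three values sits at this limit.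

The step under study leads from compound 2 to a compound that has not yet been measured, compound 4 `CCN1CC(NC(=O)[C@@H]2CCCN(S(=O)(=O)c3ccc(S(=O)(=O)N(CC)CC)cc3)C2)C1`. The change is confined to one place: 1-ethylazetidin-3-yl in place of 1-(tert-butoxycarbonyl)pyrrolidin-3-yl on an amide-type nitrogen. Among the compounds with values here, no step between measured compounds matches this change, so there is no directly comparable pair to draw on.

With nothing measured that mirrors this change, a cautious expectation is a modest weakening in this assay, somewhat beyond the scatter, estimated as a 2.5-fold higher number from compound 2 to compound 4 (0.40 log units; beyond the scatter). Compound 4 is therefore expected to give about 500 nM, with a plausible range from 150 nM to 2000 nM.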

Compound 4, half-maximal inhibitory concentration: > 30000 nM
Compound 4: no number, only a limit (the forecaster's own chance of this, stated with the estimate: 10%); middle value at least 60-fold (1.77 log units) from the limit.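

In this assay compound 4 gives no number, only a limit, > 30000 nM. Within the data shown here, putting 1-ethylazetidin-3-yl in place of 1-(tert-butoxycarbonyl)pyrrolidin-3-yl on the amide-type nitrogen gives an at least 150-fold higher number from compound 2 to compound 4 (2.17 log units; beyond the scatter), a large step, and it shows what the earlier compounds could not: the group at this position is not a neutral passenger, since this one change is enough to take a compound with a measurable value in this cell assay to one without. As far as these compounds go, the printed step marks only the smallest size the change can have, and its true size stays unknown because compound 4 gives a limit rather than a number: the limit of > 30000 nM in this assay, at which 2 of the 4 values shown sit.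

The compounds shown leave open which part of the change counts, since the five-membered ring becomes a four-membered ring and tert-butoxycarbonyl gives way to ethyl in the same step. A 1-(tert-butoxycarbonyl)azetidin-3-yl group or a 1-ethylpyrrolidin-3-yl group on the same amide-type nitrogen would each change only one of these two features, and so could tell them apart.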